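Swapping the azepane amine for methylpyrrolidine

The source may report more compounds than this note shows. Statements on the series, on what has been measured and on what is new or still open speak of the compounds shown alone.

In a functional assay on MCF7 cells (Homo sapiens) for antiproliferative activity, read by CellTiter-Glo, with a stated time of 5 days (on this read-out lower numbers stand for stronger inhibition and higher numbers for weaker inhibition), compound 1 `CC1=C(c2cccc(O)c2)[C@H](c2ccc(OC[C@H](C)N3CC[C@@H](C)C3)cc2)Oc2ccc(O)cc21` gives 0.1 nM and compound 2 `CC1=C(c2cccc(O)c2)C(c2ccc(OC[C@H](C)N3CCCCCC3)cc2)Oc2ccc(O)cc21` gives 0.2 nM so these two values lie within the scatter of each other. Compound 3 `CC1=C(c2cccc(O)c2)C(c2ccc(OC[C@H](C)N3CC[C@H](C)C3)cc2)Oc2ccc(O)cc21` differs from compound 2 by 3-methylpyrrolidin-1-yl in place of azepan-1-yl on a saturated chain carbon bound to two saturated chain carbons and has no measured value yet. Among the compounds with values here, no measured step isolates this amine change, so the expectation rests only on those two close values. In this assay the expected move is a slight rise in the number a 1.5-fold higher number from compound 2 to compound 3 (0.18 log units; within the scatter) that stays within the scatter. For compound 3 the estimate is 0.3 nM with an expected range from 0.1 nM to 1 nM in this read-out.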

Compound 3, half-maximal inhibitory concentration: 0.2 nM
Estimate against measurement, compound 3: 1.5-fold (0.18 log units) above, within the range that was stated.
By their numbers in this assay, from the lowest: compounds 1, 2 and 3 (each within the scatter of the next).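

In this assay, 3-methylpyrrolidin-1-yl in place of azepan-1-yl on a saturated chain carbon bound to two saturated chain carbons leaves the value in place (no change at the digits printed from compound 2 to compound 3 (within the scatter)), so azepan-1-yl is not needed for activity at this level. Compound 1 and compound 3 have the same atoms and bonds and also stay within the scatter (a 2.0-fold higher number from compound 1 to compound 3 (0.30 log units; within the scatter)). This pair gives no clean reading of the stereocentres because their drawn configurations are not equally defined: the fact that one of compounds 1 and 3 is drawn with a defined configuration and the other without, at the place where they differ

Still open, as far as these compounds go, is whether an open-chain amine such as dimethylamino, or a piperidine, would hold this value at the same place. Also open, from the compounds shown here alone, is whether the separate, fully defined stereoisomers of compound 3 differ from one another.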